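A few compounds are considered here, and "the series" means these few. Any claim that something is new, unique, unknown or untested is made for them only; others in the source may bear on it.

Measured compounds:
compound 1, `COc1cc(Nc2cc(Nc3ccc(Oc4ccncc4-c4cccnc4)c(F)c3)ncn2)cc(OC)c1`; in a functional assay on MKN-45 cells (Homo sapiens) for cytotoxicity, read by MTT assay, with a stated time of 72 h (a higher number here means a weaker inhibitor, a lower number a stronger inhibitor), compound 1 gives 1750 nM
compound 2, `Cn1c(=O)c(C(=O)Nc2ccc(Oc3ccncc3-c3cccnc3)c(F)c2)nn(-c2ccccc2F)c1=O`; in this assay compound 2 gives 4780 nM

Two compounds share the diaryl ether and the pyridine-bearing pyridine unit but differ in the group attached to the aniline. Of the two numbers, compound 2 gives the higher one; compound 1 gives the lower number, and the gap between them lies beyond the usual scatter, so compound 2 is the weaker of the pair in this assay.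

Compound 3, `Cn1c(=O)c(C(=O)Nc2ccc(Oc3ccncc3-c3cccnc3)c(F)c2)nn(-c2ccc(Cl)cc2)c1=O`, keeps the core of compound 2 and changes only the aryl group on the ring nitrogen: 4-chlorophenyl in place of 2-fluorophenyl on an aromatic nitrogen. Among the measured compounds shown here, no measured step covers this kind of exchange, so there is no direct precedent to lean on. Both compounds carry the same amide and the same ether portion, and the change keeps the heavy-atom count of the aryl group unchanged. The expected step from compound 2 to compound 3 is a 1.2-fold lower number from compound 2 to compound 3 (0.08 log units; within the scatter), that is, no change beyond the scatter. Compound 3 is estimated at 4000 nM in this assay, with a range from 1500 nM to 12000 nM.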

Compound 3, half-maximal inhibitory concentration: 1600 nM
Compound 3: middle estimate off by 2.5-fold (0.40 log units), on the high side; measured number inside the range.
By their numbers in this assay, from the lowest: compounds 3 and 1 (each within the scatter of the next); then compound 2.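

In this assay the aryl group on the aromatic nitrogen is shown to matter: with the rest of the structure held constant, 4-chlorophenyl in place of 2-fluorophenyl gives a 3.0-fold lower number from compound 2 to compound 3 (0.48 log units; beyond the scatter) and the earlier compounds offered no comparison that differed in one place. The two aryl groups match in heavy-atom count, in their single six-membered aromatic ring of carbon and in their count of hydrogen-bond donors and acceptors, so the step appears with those counts unchanged, while both the halogen and its place on the ring differ. No measured information on the origin of this step is available. 

Among the compounds shown here, the single step therefore does not separate the identity of the halogen from its place on the ring, and it gives no direction for the series beyond this one exchange. How this position responds to an unsubstituted phenyl, or to a phenyl carrying a methoxy group, a nitrile or an amine, remains open in the compounds shown.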